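The source may report more compounds than this note shows. Statements on the series, on what has been measured and on what is new or still open speak of the compounds shown alone.

Working notes on the series. In a functional assay on HepG2 cells (Homo sapiens) for antiproliferative activity, read by MTT assay, with a stated time of 48 h (a higher number here means a weaker inhibitor, a lower number a stronger inhibitor), compound 1 (`COc1ccc(-c2c(Nc3ccc(F)cc3)c3ccccc3oc2=O)cc1`) gives 35500 nM and compound 2 (`COc1ccc(-c2c(Nc3cc(OC)c(OC)c(OC)c3)c3ccc(OC)cc3oc2=O)cc1`) gives 84300 nM. Compound 3 (`COc1ccc(-c2c(Nc3ccc(F)cc3)c3ccc(OC)cc3oc2=O)cc1`) reads > 100000 nM, which is a limit of the assay and not a number. Compound 3 therefore stands only at the limit of > 100000 nM in this assay, at which 1 of the 3 values shown sits, with no exact position known.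

Compound 4 (`CCOc1ccc(Nc2c(-c3ccc(OC)cc3)c(=O)oc3cc(OC)ccc23)cc1`) differs from compound 3 by ethoxy in place of fluoro on an aromatic carbon, para to a large group. Within the data shown here, no measured step covers this swap. Among the measured compounds shown here, the only measured step is an at least 2.8-fold higher number from compound 1 to compound 3 (0.44 log units; beyond the scatter), and it is a different change, retained in compound 4, so it sets the weak starting point and gives no size for the swap. The closest guide is a comparison of values alone: compound 3 carries fluoro where compound 2 carries methoxy groups, and compound 2 has a measured 84300 nM. On that basis, a small move towards stronger inhibition in this assay is expected, though a result at the limit again would be no surprise. The expected change is an at least 1.3-fold lower number from compound 3 to compound 4 (0.12 log units; that floor lies within the scatter). For compound 4 the estimated value is 75000 nM, with an expected range of 30000 nM to 130000 nM.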

Compound 4, half-maximal inhibitory concentration: 31200 nM
The estimate for compound 4 lay 2.4-fold (0.38 log units) above the measured number; measured number inside the range.
By their numbers in this assay, from the lowest: compounds 4 and 1 (each within the scatter of the next); then compound 2. At a limit, above all of these: compound 3.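

With the methoxy on the shared core kept, the (4-fluorophenyl)amino group proves replaceable: in this assay, the change to (4-ethoxyphenyl)amino gives an at least 3.2-fold lower number from compound 3 to compound 4 (0.50 log units; beyond the scatter). Among these compounds, the earlier step concerned the methoxy on the core, so this is the only measured step at this place, on an aromatic carbon para to a large group, and it shows that a swap here can move the read-out beyond the scatter. The size of the step is only a floor, since the value of compound 3 is a limit of the assay and not a number: the limit of > 100000 nM in this assay, at which 1 of the 4 values shown sits.

On these data alone, it remains open whether the step belongs to ethoxy itself or would appear with other groups at this place, and a longer chain such as butoxy or an amine would help to tell these apart. As far as these compounds go, it is also open whether the same swap would carry over to the core of compound 1, which lacks that methoxy and gives 35500 nM with the fluoro group in place.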